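Adding a hydroxymethyl to the amide side chain

The source may report more compounds than this note shows. Statements on the series, on what has been measured and on what is new or still open speak of the compounds shown alone.

Compound 2 `CC(C)[C@H](C)NC(=O)c1ccc(C#Cc2cccc(F)c2)cn1` has an amide whose nitrogen carries a 1,2-dimethylpropyl group, joined to a core that ends in a fluorophenyl ring. In an ADME assay on HEK293 cells for agonist activity at metabotropic glutamate receptor 5 (Rattus norvegicus), read by fluorescence and calcium flux (a lower number here means a smaller maximal response, a higher number a larger maximal response), compound 2 gives 13.1%. That is the lower of the two measured numbers: compound 1 `C[C@@H](NC(=O)c1ccc(C#Cc2cc(F)ccn2)cn1)C(C)(C)O`, which has a different side chain on the amide nitrogen and a different fluorinated ring, gives 33% in this assay, a gap that lies beyond the usual scatter.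

Compound 3 `CC(C)(CO)NC(=O)c1ccc(C#Cc2cccc(F)c2)cn1` keeps the core and ring of compound 2 and changes only the group on the amide nitrogen: 1-(hydroxymethyl)-1-methylethyl in place of 1,2-dimethylpropyl on an amide-type nitrogen. The side chain of compound 1, the compound with the higher value, also carries an oxygen, and that is the only hint at hand; the ring in compound 1 differs as well, so it is not a clean comparison.

Compound 3 is therefore expected to give a larger maximal response than compound 2, with an estimated step of a number 8.9 percentage points higher from compound 2 to compound 3 (within the scatter) in this assay. The estimate for compound 3 is 22%, with a range from 8% to 40%.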

Compound 3, largest response reached (reported as efficacy), in percent of the reference or control that the assay uses: 9.3%
The estimate for compound 3 lay 12.7 percentage points above the measured number; low and high end bracket the measured number.
By their numbers in this assay, from the lowest: compounds 3 and 2 (each within the scatter of the next); then compound 1.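

Going by these compounds alone, the swap of 1,2-dimethylpropyl for 1-(hydroxymethyl)-1-methylethyl on an amide-type nitrogen gives the first comparison in which only one place differs, and in this assay it reads a number 3.8 percentage points lower from compound 2 to compound 3 (within the scatter). On this shared core, then, a side chain that carries a hydroxyl group and one made only of carbon and hydrogen cannot be told apart by their maximal response, even though the swap adds a hydrogen-bond donor and a hydrogen-bond acceptor. No measurement at hand offers an explanation for this result.

Because compound 1 differs from compound 2 and compound 3 in both its side chain and its fluorinated ring, the compounds shown cannot say which of these places accounts for the value of compound 1, nor whether this same swap would read differently on the core of compound 1. Also open, going by these compounds, is how the response would move with quite different groups on the amide nitrogen, such as a longer carbon chain, an amine or a carboxylic acid.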